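Replacing 2-Methylphenyl by 3-Methoxyphenyl: an Expected Gain

The source may hold more compounds than are shown below. What is called first, only, known or untested is meant among the compounds shown, and "the series" means these compounds.

Compound 1, `O=C1C[C@H](O)C[C@@H](/C=C/c2c(Cl)cc(Cl)cc2-c2cc(Cl)cc(Cl)c2)O1`, in an assay for inhibition of 3-hydroxy-3-methylglutaryl-coenzyme A reductase (Rattus norvegicus) (a lower number here means a stronger inhibitor, a higher number a weaker inhibitor), gives 37 nM.
Compound 2, `Cc1cc(C)cc(-c2cc(Cl)cc(Cl)c2/C=C/[C@@H]2C[C@@H](O)CC(=O)O2)c1`, gives 13 nM.
Compound 3, `Cc1ccccc1-c1cc(Cl)cc(Cl)c1/C=C/[C@@H]1C[C@@H](O)CC(=O)O1`, gives 370 nM.

Compound 3 stands highest of the three numbers: a 10-fold higher number from compound 1 to compound 3 (1.00 log units; beyond the scatter), and a 28-fold higher number from compound 2 to compound 3 (1.45 log units; beyond the scatter). Compound 4, `COc1cccc(-c2cc(Cl)cc(Cl)c2/C=C/[C@@H]2C[C@@H](O)CC(=O)O2)c1`, carries 3-methoxyphenyl in place of 2-methylphenyl on an aromatic carbon. Among the measured compounds shown here, no measured step exchanges a 2-methylphenyl for a 3-methoxyphenyl. The two steps that touch compound 3 both show the 2-methylphenyl far above the 3,5-dichlorophenyl of compound 1 and the 3,5-dimethylphenyl of compound 2, while a 2.8-fold lower number from compound 1 to compound 2 (0.45 log units; beyond the scatter) separates those two only modestly. Compound 4 is therefore expected to move back toward the range of compound 1 and compound 2, with a 7.4-fold lower number from compound 3 to compound 4 (0.87 log units; beyond the scatter). The estimate for compound 4 is 50 nM, between 15 nM and 200 nM.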

Compound 4, half-maximal inhibitory concentration: 50 nM
Compound 4: middle estimate and measured number agree at the digits printed; low and high end bracket the measured number.
By their numbers in this assay, from the lowest: compound 2; then compounds 1 and 4 (each within the scatter of the next); then compound 3.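

In this assay, the high number of compound 3 proves not to hold for every phenyl group with one substituent, with a 7.4-fold lower number from compound 3 to compound 4 (0.87 log units; beyond the scatter) on exchanging 2-methylphenyl for 3-methoxyphenyl. The 3-methoxyphenyl cannot be separated from the 3,5-dichlorophenyl, with a 1.4-fold higher number from compound 1 to compound 4 (0.13 log units; within the scatter) and so no order between them, but it trails the 3,5-dimethylphenyl, with a 3.8-fold higher number from compound 2 to compound 4 (0.59 log units; beyond the scatter) at this place. Nothing measured here explains these differences. From the compounds shown here alone, whether the gain follows the methoxy group or where it sits stays open, as does how a 3-aminophenyl would compare.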